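Alkynyl-Linked Pyridyl Variants on a Shared Amide Core

The source may report more compounds than this note shows. Statements on the series, on what has been measured and on what is new or still open speak of the compounds shown alone.

Measured so far:
- compound 1, `Cc1ccc(-n2nccn2)c(C(=O)N2C[C@H](C#Cc3cncc(CO)c3)CC[C@H]2C)c1`, gives "not determined" (no result reported) in a functional assay on isolated protein for antagonist activity at Orexin receptor type 2 (Homo sapiens), read by FLIPR and calcium flux; on this read-out higher numbers stand for weaker inhibition and lower numbers for stronger inhibition
- compound 2, `Cc1ccc(-n2nccn2)c(C(=O)N2C[C@H](C#Cc3cnccc3O)CC[C@H]2C)c1`, gives 52 nM in this assay
- compound 3, `Cc1ccc(-n2nccn2)c(C(=O)N2C[C@H](C#Cc3cccnc3O)CC[C@H]2C)c1`, gives "not determined" (no result reported) in this assay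

Among the compounds with values here, compound 3 stands without a number on this read-out, and compound 1 likewise carries no result, so compound 2 supplies the only value in the set. Within the data shown here, no step between two measured compounds can be drawn from these data; the only anchor for the series is the value of compound 2.

Compound 4, `Cc1ccc(-n2nccn2)c(C(=O)N2C[C@H](C#Cc3ccc(F)cn3)CC[C@H]2C)c1`, is not yet measured. It differs from compound 3 by one exchange on the alkyne: 5-fluoropyridin-2-yl in place of 2-hydroxypyridin-3-yl on a triple-bonded carbon. With compound 3 lacking a number, the size of this step cannot be placed against the scatter of this assay; the nearest reference is the value of compound 2, whose pyridyl group also carries a hydroxy substituent. On that basis a modest move toward weaker inhibition, or none beyond the scatter, is expected rather than a large shift in either direction.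

Compound 4 is expected to give about 90 nM in this assay, with a range from 25 nM to 400 nM.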

Compound 4, half-maximal inhibitory concentration: 24 nM
The estimate for compound 4 lay 3.8-fold (0.57 log units) above the measured number; measured number below the stated range.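

Working notes: a pyridyl group without a hydroxy substituent on the triple-bonded carbon still gives a measurable result in this assay, so a hydroxy group on that ring is not required for inhibition in this pair. Within the data shown here, replacing 4-hydroxypyridin-3-yl with 5-fluoropyridin-2-yl gives a 2.2-fold lower number from compound 2 to compound 4 (0.34 log units; beyond the scatter), a modest step but beyond the usual scatter, and it is the first readable step at this position; steps involving compound 1 or compound 3 cannot be read, as neither has a number. No measurement in hand explains the step.

This single exchange removes the hydroxy group, introduces fluorine and alters how the pyridyl ring is attached to the alkyne, so the contribution of each change remains unresolved. Also open, on these data alone, is how the unsubstituted pyridin-2-yl group, or a 5-aminopyridin-2-yl or 5-chloropyridin-2-yl group, would read at the same triple-bonded carbon in this assay, which would help separate the fluorine from the ring attachment.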